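Replacing a difluorophenyl with a furan on a thiophene core

This account rests on a few compounds, and the source may have more. Where it says the series, first, only, none or still open, it means among the compounds named here.

Measured so far:
compound 1, `Cc1c(Br)sc(N)c1C(=O)c1ccc(Cl)cc1`, 1%
compound 2, `CC(C)(C)Cc1c(-c2c(F)cccc2F)sc(N)c1C(=O)c1ccc(Cl)cc1`, 1%

Of the compounds shown here, two sharing one core have been tested in an assay on CHO cells for displacement of a labelled ligand from adenosine receptor A3 (Homo sapiens), read by scintillation counting, tested at 10 uM; on this read-out lower numbers stand for less inhibition and higher numbers for more inhibition at the one concentration tested (going by the name of the read-out). Compound 1 carries a bromine on the ring carbon where compound 2 carries a 2,6-difluorophenyl group, and compound 2 also bears a neopentyl group in place of a methyl group. Despite these two differences, compound 2 gives 1% and compound 1 gives 1% in this assay, so compound 2 stands level with compound 1 at the digits shown, within the usual scatter. Neither compound shows appreciable inhibition at the single concentration tested.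

Compound 3, `CC(C)(C)Cc1c(-c2ccco2)sc(N)c1C(=O)c1ccc(Cl)cc1`, has not yet been measured. It differs from compound 2 in one place: furan-2-yl in place of 2,6-difluorophenyl on an aromatic carbon. Since compound 1 and compound 2 both sit at the floor of the read-out in this assay, the expectation for this step from compound 2 to compound 3 is a change of a number 1 percentage points higher from compound 2 to compound 3 (within the scatter), which is no step beyond the scatter. Compound 3 is therefore expected to give about 2% in this assay, with a range from 0% to 12%.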

Compound 3, a percentage reported as inhibition, at one concentration (the size of the read-out at that concentration, not a potency): 1%
Beside the measured number, compound 3's estimate is 1 percentage points above it, and the stated range covers the measured number.
By their numbers in this assay, from the lowest: compounds 1, 2 and 3 (each within the scatter of the next).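

Among these compounds, this is the first reading of a change in one place only, since compound 1 and compound 2 differ in two. In this assay, putting furan-2-yl in place of 2,6-difluorophenyl, on the aromatic carbon next to the ring sulfur, gives no change at the digits printed from compound 2 to compound 3 (within the scatter) even though the group entering is a smaller ring with a hydrogen-bond acceptor that the group leaving lacks. Both values lie at the very bottom of the read-out, so this step shows that neither ring brings appreciable inhibition at the one concentration tested on this core, but it cannot separate the two groups from each other, and nothing measured here offers an explanation for the result.

Going by these compounds, whether any group on this aromatic carbon can raise the number remains open, for example an amine or a carboxylic acid in place of the furan-2-yl. Also open, on these data alone, is whether replacing the neopentyl group with a longer chain or a cyclohexyl ring would change the reading while furan-2-yl stays in place.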